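From a Fluorophenyl to a Dimethoxyphenyl Amide

A few compounds are considered here, and "the series" means these few. Any claim that something is new, unique, unknown or untested is made for them only; others in the source may bear on it.

Compound 2 `Cc1nc(C)c(/C=C/C(=O)c2ccc(NC(=O)c3ccccc3F)cc2)nc1C` was tested in a functional assay on A549 cells (Homo sapiens) for antiproliferative activity, read by CCK-8 assay, with a stated time of 72 h (a higher number here means a weaker inhibitor, a lower number a stronger inhibitor), and gave 7390 nM. Among the two numbers measured so far, compound 2 stands level with compound 1 `COc1cc(C(=O)Nc2ccc(C(=O)/C=C/c3nc(C)c(C)nc3C)cc2)cc(OC)c1OC`, which gives 7350 nM in this assay; the two values lie within the usual scatter of each other, so nothing separates them. Compound 3 `COc1ccc(C(=O)Nc2ccc(C(=O)/C=C/c3nc(C)c(C)nc3C)cc2)cc1OC` has not yet been measured. It differs from compound 2 in one place: 3,4-dimethoxyphenyl in place of 2-fluorophenyl on a carbonyl carbon. No change of this kind has been measured here, so the expected step from compound 2 to compound 3 in this assay is a 1.1-fold lower number from compound 2 to compound 3 (0.02 log units; within the scatter), meaning no movement beyond the scatter, because compound 1 gives 7350 nM while carrying a related methoxy-bearing group. Compound 3 is therefore expected to give about 7000 nM in this assay, with a likely range from 3000 nM to 16000 nM.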

Compound 3, half-maximal inhibitory concentration: 5060 nM
Compound 3: middle estimate off by 1.4-fold (0.14 log units), on the high side; the measured number falls inside the stated range.
By their numbers in this assay, from the lowest: compounds 3, 1 and 2 (each within the scatter of the next).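

In this assay, the swap on the carbonyl carbon of 3,4-dimethoxyphenyl for 2-fluorophenyl gives a 1.5-fold lower number from compound 2 to compound 3 (0.16 log units; within the scatter), so this exchange of one aromatic ring for another does not move the number beyond the scatter. The compounds also offer a second, smaller comparison at the same ring: hydrogen in place of methoxy on an aromatic carbon gives a 1.5-fold lower number from compound 1 to compound 3 (0.16 log units; within the scatter), so this single methoxy group makes no difference that can be told from the scatter. Nothing measured here offers an explanation for these results.

On these data alone, all three compounds carry a six-membered aromatic ring of carbon at this position, so the effect of a different kind of group there remains unknown. An amine, a carboxylic acid or a saturated ring such as cyclohexyl might or might not move the number beyond the scatter.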